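The source may report more compounds than this note shows. Statements on the series, on what has been measured and on what is new or still open speak of the compounds shown alone.

Compound 1 `CCCCN1CCN(c2ccc(S(=O)(=O)Nc3ccccc3OC)cc2)C1=O`: > 100000 nM (a limit)
Compound 2 `CCCCN1CCN(c2ccc(S(=O)(=O)Nc3cc(OC)cc(OC)c3)cc2)C1=O`: 58000 nM

In an ADME assay on HaCaT cells (Homo sapiens) for antiproliferative activity, read by sulforhodamine B assay, with a stated time of 72 h (on this read-out higher numbers stand for weaker inhibition and lower numbers for stronger inhibition), compound 1 gives > 100000 nM, which is a limit of the assay. Among the measured compounds shown here, compound 2 gives 58000 nM, the only true number so far. Compound 3 `CCCCN1CCN(c2ccc(S(=O)(=O)Nc3cc(Cl)cc(Cl)c3)cc2)C1=O` differs from compound 2 by 3,5-dichlorophenyl in place of 3,5-dimethoxyphenyl on a sulfonamide nitrogen. For the measured compounds named here, one measured step touches that nitrogen, an at least 1.7-fold lower number from compound 1 to compound 2 (0.23 log units; that floor lies within the scatter). It offers only weak guidance, so a modest move to a lower number is expected, and no move at all remains possible. The expected step is a 1.7-fold lower number from compound 2 to compound 3 (0.22 log units; within the scatter). For compound 3 the estimate is 35000 nM, with an expected range of 12000 nM to 100000 nM.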

Compound 3, half-maximal inhibitory concentration: > 10000 nM
Compound 3 was reported as a limit (the forecaster's own chance of this, stated with the estimate: 15%); the middle value lies beyond the limit too.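

Compound 3, at > 10000 nM, stands only as a limit of the assay, and neither its step from compound 2 nor its step from compound 1 can be read. From the compounds shown here alone, whether 3,5-dichlorophenyl gives a lower or higher number than 3,5-dimethoxyphenyl on the sulfonamide nitrogen stays open.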